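From an Amino Ester Chain to Methoxy

The source may report more compounds than this note shows. Statements on the series, on what has been measured and on what is new or still open speak of the compounds shown alone.

Measured so far in an ADME assay on HepG2 cells (Homo sapiens) for cytotoxicity; a higher number here means that more compound is tolerated, a lower number that less compound is tolerated:
- Compound 1 `CC(C)(C)CC#Cc1cc2ncnc(Nc3ccc(OCc4cccc(F)c4)c(Cl)c3)c2s1` gives 29.3 uM as a number
- Compound 2 `CC(C)CC#Cc1cc2ncnc(Nc3ccc(OCc4cccc(F)c4)c(Cl)c3)c2s1` gives > 32 uM as a limit
- Compound 3 `CCOC(=O)CN(C)CC#Cc1cc2c(Nc3ccc(OCc4cccc(F)c4)c(Cl)c3)ncnc2s1` gives > 28 uM as a limit

Compound 3 therefore has no exact value, and its reading of > 28 uM is only a limit. Compound 4 (`COCC#Cc1cc2c(Nc3ccc(OCc4cccc(F)c4)c(Cl)c3)ncnc2s1`) has methoxy in place of ((ethoxycarbonyl)methyl)(methyl)amino on a saturated chain carbon bound to a triple-bonded carbon. Among the compounds with values here, only one measured step is available, and it is an at least 1.0-fold higher number from compound 1 to compound 2 (0.03 log units; that floor lies within the scatter) and lies within the scatter at its floor. That step exchanges hydrogen for methyl on a different chain and leaves this group untouched, so it offers only weak guidance. No step beyond the scatter is therefore expected in this assay and no direction can be assigned. The estimated step is a step that the limit leaves unreadable from compound 3 to compound 4 and is expected to stay within the scatter. The estimated value for compound 4 is 30 uM with an expected range from 15 uM to 45 uM and a fair chance of it being only a limit.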

Compound 4, half-maximal toxic concentration: 9.5 uM
The estimate for compound 4 lay 3.2-fold (0.50 log units) above the measured number; the whole stated range lies above it.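

In this assay, the group on a saturated chain carbon bound to a triple-bonded carbon proves able to shift the reading: methoxy in place of ((ethoxycarbonyl)methyl)(methyl)amino gives an at least 2.9-fold lower number from compound 3 to compound 4 (0.46 log units; beyond the scatter). The one earlier step, on a different chain, lay within the scatter at its floor, so this is the only change shown that reaches beyond the scatter. Its true size stays unknown, because the reading for compound 3 is a limit: the limit of > 28 uM in this assay, at which 1 of the 4 values shown sits.

The compounds shown leave open which part of the ((ethoxycarbonyl)methyl)(methyl)amino group matters, as its amine and its ester leave together. A carboxylic acid in place of the ethyl ester, a simple dimethylamino group or a longer ether chain at this place would separate those parts.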